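A Nitrophenyl Disulfide Gives Way to an Aminoethyl One

The compounds below may be only part of what the source reports. "The series", "measured", "known", "first", "only" and "open" are said of these compounds alone.

Measured compounds:
compound 1, `Cc1cn([C@H]2C[C@H](SSc3ccc([N+](=O)[O-])cc3)[C@@H](CO)O2)c(=O)[nH]c1=O`; a physicochemical assay for metabolic stability, in the presence of a further agent that is not named here; a higher number here means that the compound lasts longer, a lower number that the compound disappears faster: < 0.167 h
compound 2, `C=CCSS[C@H]1C[C@H](n2cc(C)c(=O)[nH]c2=O)O[C@@H]1CO`; this assay: < 8 h
compound 3, `Cc1cn([C@H]2C[C@H](SSCCN)[C@@H](CO)O2)c(=O)[nH]c1=O`; not yet measured

In this assay compound 1 gives < 0.167 h, which is a limit of the assay. Compound 2 likewise gives < 8 h, also a limit. The step that the two limits leave unreadable from compound 1 to compound 2 therefore has no readable size, as the limit of < 0.167 h in this assay, at which 1 of the 2 values shown sits, and the limit of < 8 h in this assay, at which 1 of the 2 values shown sits, show. Compound 3 differs from compound 1 by 2-aminoethyl in place of 4-nitrophenyl on a sulfur. For the measured compounds named here, with both known values sitting at limits, no measured step bears readably on this change, so the expectation for compound 3 rests on the limit of compound 1 alone; compound 3 is estimated at 1 h, between 0.15 h and 8 h. The step of an at least 5.9-fold higher number from compound 1 to compound 3 (0.77 log units; beyond the scatter) is thus expected to be a lengthening.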

Compound 3, half-life: < 8 h
Compound 3: no number, only a limit; the forecaster's own chance of this, stated with the estimate: 40%; the middle value lies beyond the limit too.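

In this assay compound 3 gives < 8 h as a limit of the assay. The steps to compound 3 from compound 1 and from compound 2 cannot be read. As far as these compounds go, how long each of the three compounds actually lasts, and their order, stays open.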